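A few compounds are considered here, and "the series" means these few. Any claim that something is new, unique, unknown or untested is made for them only; others in the source may bear on it.

Compound 1 `CCc1cccc2c(=O)c(-c3nn[nH]n3)c[nH]c12`: > 25 mg/kg
Compound 2 `CS(=O)(=O)c1cccc2c(=O)c(-c3nn[nH]n3)c[nH]c12`: > 25 mg/kg

In a functional assay on the whole organism (strain Sprague-Dawley) for inhibition, with Rattus norvegicus as the target (a higher number here means that more compound is needed for the effect, a lower number that less compound is needed), compound 1 gives no number, only a limit, > 25 mg/kg. Compound 2 likewise gives only a limit in this assay, > 25 mg/kg. Within the data shown here, both measured values therefore sit at the limit of > 25 mg/kg in this assay, at which 2 of the 2 values shown sit, and the one step between them, a step that the two limits leave unreadable from compound 1 to compound 2, cannot be read: neither its size nor its direction is known. Compound 2 thus stands at the top of what this assay reports, without a number of its own.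

Compound 3 `CC(C)Oc1cccc2c(=O)c(-c3nn[nH]n3)c[nH]c12` differs from compound 2 in one place: isopropoxy in place of methylsulfonyl on an aromatic carbon. Among the measured compounds shown here, the only measured step that bears on this change is the one from compound 1 to compound 2, and it is unreadable, so no size or direction can be taken from it. With compound 1 and compound 2 both at the same limit, there is no ground to expect a step beyond the scatter in this assay; the estimated step is a step that the limit leaves unreadable from compound 2 to compound 3. Compound 3 is therefore expected to give about 30 mg/kg in this assay, estimated between 8 mg/kg and 120 mg/kg, most likely again as a limit rather than a number.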

Compound 3, minimum effective dose: 1.25 mg/kg
Estimate against measurement, compound 3: 24-fold (1.38 log units) above, outside the stated range (below it).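

At this aromatic carbon of the shared core, the choice of group now determines whether this assay returns a number at all: isopropoxy in place of methylsulfonyl gives an at least 20-fold lower number from compound 2 to compound 3 (1.30 log units; beyond the scatter), and isopropoxy in place of ethyl gives an at least 20-fold lower number from compound 1 to compound 3 (1.30 log units; beyond the scatter). Each of these steps starts from a limit, so its true size may be larger than printed, while the step between the ethyl and methylsulfonyl compounds still cannot be read. What the earlier pair could not show is that this position responds to a change of group at all, for until now the only reading was a shared limit: the limit of > 25 mg/kg in this assay, at which 2 of the 3 values shown sit.

The compounds shown leave open whether the oxygen of isopropoxy or its carbon part carries the step, and methoxy, a longer chain such as propoxy, or an amine at this carbon would help to separate the two. As far as these compounds go, only compound 3 has a number of its own in this assay, so it also remains open how much further the minimum effective dose could move with other groups here.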